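A few compounds are considered here, and "the series" means these few. Any claim that something is new, unique, unknown or untested is made for them only; others in the source may bear on it.

Working notes on the series. In a functional assay on HeLa cells (Homo sapiens) for antiproliferative activity, read by MTT assay, with a stated time of 48 h (on this read-out lower numbers stand for stronger inhibition and higher numbers for weaker inhibition), compound 1 (`Brc1ccc(CSc2nnc(-c3cnccn3)o2)cc1`) gives 21600 nM and compound 2 (`Fc1ccccc1CSc1nnc(-c2cnccn2)s1`) gives 32700 nM while compound 3 (`Clc1ccccc1CSc1nnc(-c2cnccn2)s1`) gives 28900 nM on the same read-out. Compound 2 has no separate place among these numbers, since its value lies within the scatter of both others.

Compound 4 (`Fc1ccc(CSc2nnc(-c3cnccn3)s2)c(F)c1`) departs from compound 2 by a single change: fluoro in place of hydrogen on an aromatic carbon with the new fluoro on an aromatic carbon, meta to a fluoro group and para to a large group.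

Within the data shown here, only one measured step bears on this. Chloro in place of fluoro on an aromatic carbon gave a 1.1-fold lower number from compound 2 to compound 3 (0.05 log units; within the scatter) as its result, but that is an exchange and not an added group. Among the measured compounds shown here, compound 1 differs from compound 2 in more than one place and gives no clean step. The effect of adding fluoro in place of hydrogen has not been measured in this series.

For the measured compounds named here, no shift beyond the scatter is therefore expected in this assay because a 1.1-fold lower number from compound 2 to compound 3 (0.05 log units; within the scatter) is the only single-place step available. The expected change is a 1.2-fold lower number from compound 2 to compound 4 (0.08 log units; within the scatter) by this estimate. For compound 4 the estimated value is 27000 nM with an expected range from 13000 nM to 52000 nM in this read-out.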

Compound 4, half-maximal inhibitory concentration: 20900 nM
Compound 4: the middle estimate sits 1.3-fold (0.11 log units) above what was measured, and the stated range covers the measured number.
By their numbers in this assay, from the lowest: compounds 4, 1, 3 and 2 (each within the scatter of the next).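

Among these compounds, this is the first measured step that adds a group rather than exchanging one: in this assay fluoro in place of hydrogen on an aromatic carbon, meta to a fluoro group and para to a large group, gives a 1.6-fold lower number from compound 2 to compound 4 (0.19 log units; within the scatter) and so does not set compound 4 apart from compound 2. Together with the exchange of fluoro for chloro, which gave a 1.1-fold lower number from compound 2 to compound 3 (0.05 log units; within the scatter) on the same read-out, this means that neither single change on the aromatic ring of compound 2 has moved the number beyond the scatter, a statement that holds only for these compounds. No measurement is available that bears on the reason for this result.

The compounds shown leave open whether a group other than a halogen at this position, such as methoxy, an amine or a carboxylic acid, would give a step beyond the scatter. Among the compounds shown here, they also leave open whether fluoro in place of hydrogen at this position would give a similar step on the core of compound 1, since no single-place step links that core to compound 2 or compound 4.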